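This account rests on a few compounds, and the source may have more. Where it says the series, first, only, none or still open, it means among the compounds named here.

In an assay on isolated protein for inhibition of Trypsin (Homo sapiens), read by fluorescence, with a stated time of 15 min, tested at 50 uM (on this read-out higher numbers stand for more inhibition at the one concentration tested (going by the name of the read-out) and lower numbers for less inhibition), the measured compounds gave:

compound 1 `N=C(N)NCCC[C@H](NC(=O)c1ccccc1)C(=O)N(CCCCN)CC(=O)N[C@@H](C(N)=O)c1ccccc1`: 10.6%
compound 2 `N=C(N)NCCCN(CC(=O)N[C@@H](CCCCN)C(=O)N[C@@H](C(N)=O)c1ccccc1)C(=O)c1ccccc1`: a limit of the assay, <= 5%
compound 3 `C[C@](NC(=O)[C@H](CCCCN)NC(=O)[C@H](CCCNC(=N)N)NC(=O)c1ccccc1)(C(N)=O)c1ccccc1`: 11.8%

Only two of the three results are numbers. Compound 2 does not give a number in this assay; its result is a limit, and the limit of <= 5% in this assay, at which 1 of the 3 values shown sits, describes where it sits. Compound 3 and compound 1 both give numbers, and the gap between them is within the usual scatter of repeated measurements, so the two cannot be told apart on this evidence. All three compounds share the same atoms and bonds as compound 4, except that compound 4 `CC(NC(=O)[C@H](CCCCN)NC(=O)[C@H](CCCNC(=N)N)NC(=O)c1ccccc1)(C(N)=O)c1ccccc1` has not yet been tested in this assay.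

Compound 4 differs from compound 3 only in stereochemistry: the two compounds have the same atoms and bonds; at least one stereo element is drawn with a configuration in one of them and without one in the other: 1 of 4 stereo elements differ; a stereocentre at a saturated chain carbon is drawn R in compound 3 and without a configuration in compound 4. No atom leaves and none enters. Going by the values given here, since no step between two measured compounds of this kind is recorded, the account has nothing to lean on except the change itself. Where one drawn configuration is replaced by none, the expected step from compound 3 to compound 4 is estimated as small, a number 2.8 percentage points lower from compound 3 to compound 4 (within the scatter), and not beyond the scatter, if anything slightly downward. Compound 4 is therefore expected to give about 9% in this assay, within a range from 3% to 15%.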

Compound 4, a percentage reported as inhibition, at one concentration (the size of the read-out at that concentration, not a potency): <= 5%
Compound 4 ended at the assay's limit (the forecaster's own chance of this, stated with the estimate: 25%); middle value at least 4 percentage points from the limit.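

Going by these compounds alone, this pair is the first in this assay to isolate a single place on the shared core, with no atom leaving or entering, and only one thing separates the two compounds: the fact that one of compounds 3 and 4 is drawn with a defined configuration and the other without, at the place where they differ Across that one place the reading is a number at least 6.8 percentage points lower from compound 3 to compound 4 (that floor lies within the scatter), so the step has a floor but no fixed size, and that floor does not establish a change beyond the scatter. Compound 4 gives <= 5%, which is a limit of the assay and not a number, so this position can be said to allow a drop of uncertain size when the drawn R configuration gives way to none, but not to require one.

The compounds shown leave open how a compound drawn with the opposite configuration at this stereocentre would read, since compound 4 carries no drawn configuration there and so cannot stand in for it. They also leave open how the read-out would respond to a different group at that stereocentre, such as an ethyl group or a carboxylic acid.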